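A few compounds are considered here, and "the series" means these few. Any claim that something is new, unique, unknown or untested is made for them only; others in the source may bear on it.

Of the compounds shown here, three have so far been measured in a functional assay on HeLa cells (Homo sapiens) for antiproliferative activity, read by MTT assay, with a stated time of 48 h; a higher number here means a weaker inhibitor, a lower number a stronger inhibitor. Compound 1 `CNCC(=O)Nc1cc(OC)ccc1C(=O)c1cc(OC)c(OC)c(OC)c1` gives 690 nM in this assay. Compound 2 `CCNCC(=O)Nc1cc(OC)ccc1C(=O)c1cc(OC)c(OC)c(OC)c1` carries a single change relative to compound 1, (methyl in place of hydrogen on a saturated chain carbon bound to an amine nitrogen), and in this assay compound 2 gives 2100 nM. That one change produced a 3.0-fold higher number from compound 1 to compound 2 (0.48 log units; beyond the scatter). Compound 3 `C=C(c1ccc(OC)cc1NC(=O)CNC)c1ccc(OC)c2c1C=CC(C)(C)O2` rests on a different core; the difference between the core of compound 1 and the core of compound 3 is not broken down here. In this assay compound 3 gives 500 nM, a number within the scatter of the value of compound 1 and beyond the scatter from the value of compound 2.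

Compound 4 `C=C(c1ccc(OC)cc1NC(=O)CNCC)c1ccc(OC)c2c1C=CC(C)(C)O2` is the untested partner of compound 3: it differs from compound 3 by methyl in place of hydrogen on a saturated chain carbon bound to an amine nitrogen. This is the same change that separates compound 1 from compound 2, made at the same place, and it occurs twice among these compounds. Going by the values given here, the one measured instance, a 3.0-fold higher number from compound 1 to compound 2 (0.48 log units; beyond the scatter), was a modest weakening. Compound 4 is therefore expected to be a somewhat weaker inhibitor than its parent, with an expected step of a 3.0-fold higher number from compound 3 to compound 4 (0.48 log units; beyond the scatter) in this assay, because on the first core the same change gave a 3.0-fold higher number from compound 1 to compound 2 (0.48 log units; beyond the scatter). The expectation rests on one precedent carried over to a different core, so it is held loosely. Compound 4 is estimated at 1500 nM, expected to fall between 700 nM and 3500 nM.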

Compound 4, half-maximal inhibitory concentration: 2590 nM
Compound 4: the middle estimate sits 1.7-fold (0.24 log units) below what was measured; measured number inside the range.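

In this assay, the change from methylamino to ethylamino again gave a weaker inhibitor on the second core, with a 5.2-fold higher number from compound 3 to compound 4 (0.71 log units; beyond the scatter), so the loss seen on the core of compound 1 was also seen on the core of compound 3. Set side by side, the two steps point the same way and their sizes cannot be told apart: the same change on two cores in this assay, a 3.0-fold higher number (0.48 log units; beyond the scatter) from compound 1 to compound 2 and a 5.2-fold higher number (0.71 log units; beyond the scatter) from compound 3 to compound 4, 1.7-fold (0.23 log units) apart, within the scatter of two such steps This shows that, for these two cores and in this one cell assay, the step measured on one core was a fair guide to the direction and rough size of the step on the other, but two pairs do not establish a rule for other cores or other read-outs, and they say nothing about why the ethylamino compounds are weaker.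

The compounds shown leave open whether the weakening continues with a longer chain such as propylamino, and how a primary amine or a dimethylamino group would compare with methylamino on either core. They also leave open whether the same change would carry the same penalty in cell lines other than the one used here.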